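The source may report more compounds than this note shows. Statements on the series, on what has been measured and on what is new or still open speak of the compounds shown alone.

In a functional assay for inhibition, with a stated time of 12 h, tested at 100 ug/mL (a higher number here means more inhibition at the concentration tested (going by the name of the read-out), a lower number less inhibition), the measured set stands as follows: compound 1 `CCC(c1ccc(O)c(OC)c1)c1cccc(O)c1O` gives 74%; compound 2 `CCOc1cccc(C(CC)c2ccc(O)c(OC)c2)c1O` gives 77%; compound 3 `CCC(c1ccc(O)c(OC)c1)c1ccccc1O` gives 75%.

Compound 3 sits second highest of the three, with compound 1 nearest, a number 1 percentage points higher from compound 1 to compound 3 (within the scatter), and compound 2 furthest, a number 2 percentage points lower from compound 2 to compound 3 (within the scatter); all three lie within the scatter of one another, so no order among them is claimed.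

Compound 4 `CCC(c1ccc(O)c(OC)c1)c1ccc(O)cc1O` differs from compound 3 by hydroxy in place of hydrogen on an aromatic carbon. The measured step that bears on this is the reverse exchange, a number 1 percentage points higher from compound 1 to compound 3 (within the scatter), which stayed within the scatter; a number 2 percentage points lower from compound 2 to compound 3 (within the scatter) likewise stayed within the scatter. Hence no step beyond the scatter is expected in either direction, the expected step being no change at the digits printed from compound 3 to compound 4 (within the scatter). Compound 4 is estimated at 75%, with a range from 64% to 86%.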

Compound 4, a percentage reported as inhibition, at one concentration (the size of the read-out at that concentration, not a potency): 75%
Compound 4: the middle estimate sits on the measured number at the digits printed, within the range that was stated.
By their numbers in this assay, from the lowest: compounds 1, 3, 4 and 2 (each within the scatter of the next).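

In this assay hydroxy in place of hydrogen on an aromatic carbon, meta to a hydroxy group and para to a large group, gives no change at the digits printed from compound 3 to compound 4 (within the scatter) and so stays within the scatter. Within the data shown here, the earlier steps concerned a different carbon of this ring, so this is the first reading at this position. At the one concentration tested, a hydroxy here is thus compatible with a number in the range of the other compounds, though this says nothing of potency.

On these data alone, whether an amine or a carboxylic acid on this same carbon would give a step beyond the scatter remains open. Nothing on hand offers an explanation for this result.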